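A Methyl on the Ring Nitrogen, Tried Again

The source may hold more compounds than are shown below. What is called first, only, known or untested is meant among the compounds shown, and "the series" means these compounds.

Compound 1 `N=C(N)NCCCOc1ccc(CNc2nc3ccc(Oc4cccc(C(F)(F)F)c4)cc3s2)cc1` and compound 2 `CN(Cc1ccc(OCCCNC(=N)N)cc1)c1nc2ccc(Oc3cccc(C(F)(F)F)c3)cc2s1` share one core, while compound 3 `CN(C)CCCOc1ccc(CNc2nc3ccc(Oc4ccc(C#N)cc4)cc3s2)cc1` and compound 4 `CN(C)CCCOc1ccc(CN(C)c2nc3ccc(Oc4ccc(C#N)cc4)cc3s2)cc1` share another, and the difference between the two cores is not broken down here. In an assay on SH-SY5Y cells for inhibition of Voltage-dependent N-type calcium channel subunit alpha-1B (Homo sapiens), read by FLIPR and calcium flux, with stated times of 600 s and 300 s, in the presence of a further agent that is not named here (a lower number here means a stronger inhibitor, a higher number a weaker inhibitor), compound 1 gives 130000 nM, compound 2 gives 202000 nM, and compound 3 gives 105000 nM. All three numbers lie within the scatter of one another, so none can be called stronger or weaker than the rest. Compound 2 differs from compound 1 by methyl in place of hydrogen on a nitrogen on an aromatic ring, and the measured step for that change is a 1.6-fold higher number from compound 1 to compound 2 (0.19 log units; within the scatter). Compound 4 differs from compound 3 by methyl in place of hydrogen on a nitrogen on an aromatic ring, the same change at the same place, now on the other core. For the measured compounds named here, only one measured example of this change exists here, and it stayed within the scatter. Compound 4 is therefore expected to give 150000 nM, with a range from 60000 nM to 400000 nM. The expected step of a 1.4-fold higher number from compound 3 to compound 4 (0.15 log units; within the scatter) is estimated to be small, resting on the measured step of a 1.6-fold higher number from compound 1 to compound 2 (0.19 log units; within the scatter).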

Compound 4, half-maximal inhibitory concentration: 69000 nM
Compound 4: middle estimate off by 2.2-fold (0.34 log units), on the high side, within the range that was stated.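

In this assay, methyl in place of hydrogen on the nitrogen gives a 1.5-fold lower number from compound 3 to compound 4 (0.18 log units; within the scatter), a step that cannot be told apart from the ordinary spread of repeated measurements. Set beside the earlier example, the two steps have opposite signs on paper, yet the gap between them is no larger than such spread allows: the same change on two cores in this assay, a 1.6-fold higher number (0.19 log units; within the scatter) from compound 1 to compound 2 and a 1.5-fold lower number (0.18 log units; within the scatter) from compound 3 to compound 4, 2.4-fold (0.37 log units) apart, within the scatter of two such steps. This shows that the change can be carried from one core to the other without a step beyond the scatter in either case, but it does not show that the two cores respond identically, and a small real difference between them could still lie hidden within that scatter.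

The compounds shown leave open whether an ethyl or an acetyl group on that same nitrogen would give a step beyond the scatter. They also leave open whether the methyl change would stay this small on a compound carrying a carboxylic acid at the end of the chain.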